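Cinnamamide pyrazoles: bromo to methyl on the aryl ring

This account rests on a few compounds, and the source may have more. Where it says the series, first, only, none or still open, it means among the compounds named here.

Measured compounds:
compound 1, `COc1ccc(/C=C/C(=O)Nc2cc(-c3ccc(Br)cc3)[nH]n2)cc1`: 590 nM
compound 2, `O=C(/C=C/c1ccc(Br)cc1)Nc1cc(-c2ccccc2)[nH]n1`: 1240 nM
compound 3, `COc1ccc(/C=C/C(=O)Nc2cc(-c3ccc(C)cc3)[nH]n2)cc1`: 860 nM

All three were tested in a functional assay on MCF7 cells (Homo sapiens) for antiproliferative activity, read by MTT assay, with a stated time of 48 h; a higher number here means a weaker inhibitor, a lower number a stronger inhibitor. Compound 1 gives 590 nM and compound 3 gives 860 nM in this assay. The two differ by one change, (methyl in place of bromo on an aromatic carbon), and the step of a 1.5-fold higher number from compound 1 to compound 3 (0.16 log units; within the scatter) is small. Compound 2 gives 1240 nM; set against compound 3 its number lies within the scatter, set against compound 1 it lies beyond it. The difference between the core of compound 2 and the core of compound 1 is not broken down here.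

The unmeasured compound 4, `Cc1ccc(/C=C/C(=O)Nc2cc(-c3ccccc3)[nH]n2)cc1`, differs from compound 2 by methyl in place of bromo on an aromatic carbon. For the measured compounds named here, this is the same kind of change as the one from compound 1 to compound 3, made on the other aryl ring of the series, and the only measured instance of it is that single step. On that basis compound 4 is expected to stand a small step away from compound 2, about as small as the measured step of a 1.5-fold higher number from compound 1 to compound 3 (0.16 log units; within the scatter), taken together with the value of compound 2, 1240 nM. The step expected here is a 1.4-fold higher number from compound 2 to compound 4 (0.14 log units; within the scatter). Compound 4 is therefore expected to give about 1700 nM in this assay, estimated to fall between 800 nM and 3600 nM. Going by the values given here, with one example of the change and no step of the same kind on this aryl ring, the range is kept wide.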

Compound 4, half-maximal inhibitory concentration: 1780 nM
Compound 4: middle estimate off by 1.0-fold (0.02 log units), on the low side; the range from low to high includes it.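

In this assay, the change from 4-bromophenyl to 4-methylphenyl on the core of compound 2 gives a small step (a 1.4-fold higher number from compound 2 to compound 4 (0.16 log units; within the scatter)), and set beside the same change on the core of compound 1 the two steps do not differ: (the same change on two cores in this assay, a 1.5-fold higher number (0.16 log units; within the scatter) from compound 1 to compound 3 and a 1.4-fold higher number (0.16 log units; within the scatter) from compound 2 to compound 4, 1.0-fold (0.01 log units) apart, within the scatter of two such steps). Within this small set, the change therefore carries from one core to the other with its size intact, whichever of the two aryl rings holds it, and the step on one core served as a usable guide to the step on the other. This does not show that methyl and bromo differ in their effect on the read-out, since each step lies within the scatter, and two pairs of compounds give no rule for other cores or for a change that produces a larger step.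

Still open, as far as these compounds go, is whether an amine, a carboxylic acid or a longer chain in place of the bromo, para to the same large group, would carry between the two cores in the same way. The compounds shown also hold no pair differing in one place that links the core of compound 1 to the core of compound 2, so the gap between those cores remains unresolved.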